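The compounds below may be only part of what the source reports. "The series", "measured", "known", "first", "only" and "open" are said of these compounds alone.

Measured so far:
compound 1 `CC(C(=O)N1CCN(c2ccc(Cl)cc2)CC1)N1C(=O)CCC1=O`: 25%
compound 2 `CCC(C(=O)N1CCN(c2cccc(C(F)(F)F)c2)CC1)N1C(=O)CCC1=O`: 50%

In a functional assay on the whole organism (strain Swiss) with Mus musculus as the target, in the maximal electroshock model, with a stated time of 0.5 h, at a dose of 100 mg/kg by the intraperitoneal route (on this read-out higher numbers stand for a stronger effect at the one dose given and lower numbers for a weaker effect), compound 1 gives 25%, the lower of the two numbers. Compound 2, which differs from it in several places, gives 50%, a gap beyond the usual scatter. Among the measured compounds shown here, no pair of measured compounds differs in a single place, so nothing yet shows how one change alone moves this assay. Compound 3 `CC(C(=O)N1CCN(c2cccc(Cl)c2)CC1)N1C(=O)CCC1=O` differs from compound 1 in one place: 3-chlorophenyl in place of 4-chlorophenyl on an amine nitrogen in a ring. Without a measured step of this kind, the step of a number 5 percentage points higher from compound 1 to compound 3 (within the scatter) is expected to stay within the scatter. Compound 3 is expected to give 30%, in the range 10% to 55%.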

Compound 3, a percentage reported as activity, at one dose (the size of the read-out at that dose, not a potency): 75%
The estimate for compound 3 lay 45 percentage points below the measured number; measured number above the stated range.
By their numbers in this assay, from the lowest: compound 1; then compound 2; then compound 3.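

In this assay, among the compounds shown here, 3-chlorophenyl in place of 4-chlorophenyl on the amine nitrogen in the ring gives a number 50 percentage points higher from compound 1 to compound 3 (beyond the scatter) and is the first single change with a measured effect. The two groups have the same atoms and the same counts, so this position responds to how the chlorine is joined to the phenyl ring, not only to which atoms are present. No measurement given here explains the step.

From the compounds shown here alone, whether 3-bromophenyl or 3-methoxyphenyl would match 3-chlorophenyl remains open. So does whether the same change would have a similar effect with the longer chain of compound 2.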